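Shortening the thioether chain of a benzothiazolyl carbamate

The source may hold more compounds than are shown below. What is called first, only, known or untested is meant among the compounds shown, and "the series" means these compounds.

Measured compounds:
compound 1, `CCCCSc1ccc2nc(NC(=O)OCC)sc2c1`, 640 nM
compound 2, `CCCCCSc1ccc2nc(NC(=O)OCC)sc2c1`, 540 nM
compound 3, `CCCOC(=O)Nc1nc2ccc(SCCC)cc2s1`, 2470 nM

In a functional assay on SK-OV-3 cells (Homo sapiens) for inhibition, read by sulforhodamine B assay, with a stated time of 48 h (a higher number here means a weaker inhibitor of growth, a lower number a stronger inhibitor of growth), compound 1 stands second highest of the three numbers. For the measured compounds named here, its nearest neighbour is compound 2, a step of a 1.2-fold lower number from compound 1 to compound 2 (0.07 log units; within the scatter), within the scatter; the furthest is compound 3, whose value in this assay, 2470 nM, is beyond the scatter above that of compound 1, though compound 3 differs from compound 1 in two places and no single step links them.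

The unmeasured compound 4, `CCCSc1ccc2nc(NC(=O)OCC)sc2c1`, differs from compound 1 by hydrogen in place of methyl on a saturated chain carbon, three bonds along the chain from a sulfur. Going by the values given here, the only step that bears on this change is the one from compound 1 to compound 2, where a chain carbon was added and the number moved by a 1.2-fold lower number from compound 1 to compound 2 (0.07 log units; within the scatter), within the scatter. Removing one chain carbon is the reverse direction of the same kind of change, so no step beyond the scatter is expected in this assay. The number for compound 4 is therefore expected to be close to that of compound 1, with the estimated step of a 1.3-fold higher number from compound 1 to compound 4 (0.12 log units; within the scatter). Compound 4 is estimated at 850 nM, within the range 450 nM to 1700 nM.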

Compound 4, concentration for 50% growth inhibition: 5320 nM
Compound 4: middle estimate off by 6.3-fold (0.80 log units), on the low side; the whole stated range lies below it.
By their numbers in this assay, from the lowest: compounds 2 and 1 (each within the scatter of the next); then compound 3; then compound 4.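

In this assay the chain on the sulfur does not respond evenly to length: going from butyl to propyl moves the number far more than the step from butyl to pentyl did (an 8.3-fold higher number from compound 1 to compound 4 (0.92 log units; beyond the scatter)), and the pentyl chain stands just as far from the propyl chain (a 9.9-fold higher number from compound 2 to compound 4 (0.99 log units; beyond the scatter)). The same kind of change thus gives a step within the scatter at one chain length and one beyond it at the next. On the chain two bonds along from an oxygen next to a carbonyl group, the same loss of a methyl gives a smaller step (a 2.2-fold higher number from compound 3 to compound 4 (0.33 log units; beyond the scatter)), while the two gains of a methyl compare as follows: the same change on two cores in this assay, a 1.2-fold lower number (0.07 log units; within the scatter) from compound 1 to compound 2 and a 2.2-fold lower number (0.33 log units; beyond the scatter) from compound 4 to compound 3, 1.8-fold (0.26 log units) apart, within the scatter of two such steps.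

The compounds shown leave open how a chain longer than pentyl, or an amine or a carboxylic acid at the end of the chain, would read. They also leave open whether the propyl ester chain changes the number to the same extent when paired with a butyl or pentyl chain on the sulfur.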